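The source may hold more compounds than are shown below. What is called first, only, known or untested is meant among the compounds shown, and "the series" means these compounds.

Three compounds share one core and differ only in the aryl group on an aromatic nitrogen. Compound 1 `Cc1cc(=O)n(-c2ccccc2OC(F)(F)F)nc1C(=O)Nc1ccc(Oc2ncnc3ccsc23)cc1` gives 10100 nM in a functional assay on A549 cells (Homo sapiens) for cytotoxicity, read by MTT assay, with a stated time of 72 h; a higher number here means a weaker inhibitor, a lower number a stronger inhibitor. Compound 2 `Cc1cc(=O)n(-c2cccc(F)c2)nc1C(=O)Nc1ccc(Oc2ncnc3ccsc23)cc1` gives 9540 nM in this assay, and compound 3 `Cc1ccc(-n2nc(C(=O)Nc3ccc(Oc4ncnc5ccsc45)cc3)c(C)cc2=O)cc1` gives 11500 nM. The steps between them are small: a 1.1-fold lower number from compound 1 to compound 2 (0.02 log units; within the scatter), a 1.1-fold higher number from compound 1 to compound 3 (0.06 log units; within the scatter) and a 1.2-fold higher number from compound 2 to compound 3 (0.08 log units; within the scatter), each within the scatter, so compound 3 sits together with the other two rather than apart from them.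

Compound 4 `Cc1ccc(-n2nc(C(=O)Nc3ccc(Oc4ncnc5ccsc45)cc3)c(C)cc2=O)c(C)c1` has not yet been measured. It differs from compound 3 by methyl in place of hydrogen on an aromatic carbon, and the ring touched is the one that was varied across compounds 1, 2 and 3. Those three variations, of different kinds, moved this assay by nothing beyond the scatter, so this further change to the same ring is expected to behave alike. For compound 4 the expected step is a 1.0-fold lower number from compound 3 to compound 4 (0.02 log units; within the scatter), none beyond the scatter. Compound 4 is therefore estimated at 11000 nM, with a range from 5000 nM to 24000 nM.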

Compound 4, half-maximal inhibitory concentration: 16400 nM
The estimate for compound 4 lay 1.5-fold (0.17 log units) below the measured number; the range from low to high includes it.
By their numbers in this assay, from the lowest: compounds 2, 1, 3 and 4 (each within the scatter of the next).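

Adding a methyl group to an aromatic carbon, ortho to a large group and meta to the existing methyl, turns 4-methylphenyl into 2,4-dimethylphenyl and stays within the scatter in this assay (a 1.4-fold higher number from compound 3 to compound 4 (0.15 log units; within the scatter)). Compound 4 is the only compound shown with two groups on this ring, yet its other steps also stay within the scatter (a 1.7-fold higher number from compound 2 to compound 4 (0.24 log units; within the scatter); a 1.6-fold higher number from compound 1 to compound 4 (0.21 log units; within the scatter)), so all four compounds remain together in this assay. No measured evidence here explains this result.

On these data alone, whether an amine or a carboxylic acid on this ring, or a longer chain in place of the methyl, would move the number beyond the scatter remains open. As far as these compounds go, the effect of any change outside this ring, in the shared core, also remains open.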